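Swapping Chloro for Fluoro on Two Related Cores

The source may hold more compounds than are shown below. What is called first, only, known or untested is meant among the compounds shown, and "the series" means these compounds.

Compound 1 `NC(=O)c1c(NC(=O)c2ccccc2Cl)sc2c1CCN(Cc1ccc(Cl)cc1Cl)C2` gives 8010 nM in a functional assay on HL-60 cells (Homo sapiens) for antiproliferative activity, with a stated time of 24 h; a lower number here means a stronger inhibitor, a higher number a weaker inhibitor.
Compound 2 `NC(=O)c1c(NC(=O)c2ccccc2F)sc2c1CCN(Cc1ccc(Cl)cc1Cl)C2` gives 13100 nM in this assay.
Compound 3 `NC(=O)c1c(NC(=O)c2ccccc2Cl)sc2c1CCN(C(=S)Nc1cc(C(F)(F)F)cc(C(F)(F)F)c1)C2` gives 6500 nM in this assay.

Compound 1 and compound 2 share one core and differ only by fluoro in place of chloro on an aromatic carbon. That single change produced a 1.6-fold higher number from compound 1 to compound 2 (0.21 log units; within the scatter), so the two numbers cannot be told apart with confidence. Compound 3 carries the same chloro-bearing group on a different core; how its core differs from that of compound 1 is not broken down here. Its value sits within the scatter of both compound 1 and compound 2, so no order among the three can be claimed.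

Compound 4 `NC(=O)c1c(NC(=O)c2ccccc2F)sc2c1CCN(C(=S)Nc1cc(C(F)(F)F)cc(C(F)(F)F)c1)C2` has not yet been measured. It differs from compound 3 by fluoro in place of chloro on an aromatic carbon, the same change at the same place as between compound 1 and compound 2. Because the earlier step was a 1.6-fold higher number from compound 1 to compound 2 (0.21 log units; within the scatter), a step of similar size is expected here, a 1.5-fold higher number from compound 3 to compound 4 (0.19 log units; within the scatter). Compound 4 is therefore estimated at 10000 nM, with a likely range from 5000 nM to 22000 nM.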

Compound 4, half-maximal inhibitory concentration: 17900 nM
Compound 4: the middle estimate sits 1.8-fold (0.25 log units) below what was measured, and the stated range covers the measured number.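

Going from 2-chlorophenyl to 2-fluorophenyl on the core of compound 3 gave a 2.8-fold higher number from compound 3 to compound 4 (0.44 log units; beyond the scatter) in this assay. Set beside the same change on the core of compound 1, the new step points the same way and cannot be told apart from the earlier one in size: the same change on two cores in this assay, a 1.6-fold higher number (0.21 log units; within the scatter) from compound 1 to compound 2 and a 2.8-fold higher number (0.44 log units; beyond the scatter) from compound 3 to compound 4, 1.7-fold (0.23 log units) apart, within the scatter of two such steps. This fits the change carrying over between these two cores, but only the new step lies beyond the scatter on its own, and two cores cannot show that the same would hold on a third.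

The compounds shown carry only chloro or fluoro at this place on the aromatic ring, so it remains open how a methyl, a methoxy or a plain hydrogen would read there. As far as these compounds go, it also remains open whether the step would persist on a core bearing an amine, a carboxylic acid or a longer chain in place of the groups that set the two cores apart.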